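The compounds below may be only part of what the source reports. "The series", "measured", "known", "first", "only" and "open" are said of these compounds alone.

Of the compounds shown here, three have been measured in an ADME assay on PA-1 cells (Homo sapiens) for cytotoxicity, read by MTT assay, with a stated time of 72 h; a higher number here means a weaker inhibitor, a lower number a stronger inhibitor. Compound 1 `COc1ccc(C2=C(c3cc(OC)c(OC)c(OC)c3)C(=O)C(OC(C)=O)C2)cc1` gives a value that is a limit of the assay, < 1 ug/mL. Compound 2 `C=CCOc1cc(C2=C(c3cc(OC)c(OC)c(OC)c3)C(=O)C(O)C2)ccc1OC` also reaches only a limit, at > 100 ug/mL. Compound 3 `COc1ccc(C2=C(c3cc(OC)c(OC)c(OC)c3)C(=O)C(O)C2)cc1` likewise gives a limit, < 1 ug/mL, so its standing among the three is known only as a limit, and two of the three values shown are limits as well. The step that the two limits leave unreadable from compound 1 to compound 3 cannot be read from two limits. The step of an at least 100-fold lower number from compound 2 to compound 3 (2.00 log units; beyond the scatter) is large: removing the allyloxy group from the aromatic ring lowers the number by at least that much.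

Compound 4 `COc1ccc(C2=C(c3cc(OC)c(OC)c(OC)c3)C(=O)C(O)C2)cc1NC(=O)c1ccccc1` differs from compound 3 by benzamido in place of hydrogen on an aromatic carbon, a benzamido group placed ortho to a methoxy group and meta to a large group. Among the compounds with values here, the only step that bears on adding a group to this ring is an at least 100-fold lower number from compound 2 to compound 3 (2.00 log units; beyond the scatter), read in reverse: a substituent there went with a much higher number. Compound 4 is therefore expected to show an at least 10-fold higher number from compound 3 to compound 4 (1.00 log units; beyond the scatter). Compound 4 is estimated at 10 ug/mL, within the range 1 ug/mL to 100 ug/mL.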

Compound 4, half-maximal inhibitory concentration: > 100 ug/mL
Compound 4: a limit, no number; the forecaster's own chance of this, stated with the estimate: 35%; middle value at least 10-fold (1.00 log units) away from the limit.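

In this assay compound 4 gives > 100 ug/mL, which is a limit of the assay and not a number. Benzamido in place of hydrogen on this aromatic carbon, ortho to a methoxy group, brings an at least 100-fold higher number from compound 3 to compound 4 (2.00 log units; beyond the scatter), so the large rise in the number seen with allyloxy at this place is not confined to that one group, and among these compounds nothing at this position goes against it. The step between the allyloxy compound 2 and the benzamido compound 4 cannot be read, as both sit at the same limit, so the two groups cannot be ranked.

Going by these compounds, whether a much smaller group here, such as a fluorine atom or a simple amine, would keep the number low remains open. The true size of the rise also stays unknown, as the values sit at limits: the limit of > 100 ug/mL in this assay, at which 2 of the 4 values shown sit.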